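A Third Analogue Set Beside Two Cytotoxicity Limits

The source may hold more compounds than are shown below. What is called first, only, known or untested is meant among the compounds shown, and "the series" means these compounds.

Compound 1 `Cc1ccc2cc(CNCc3ccc(F)cc3)c(=O)[nH]c2c1`: > 33000 nM
Compound 2 `Cc1ccc2[nH]c(=O)c(CN(CCCO)Cc3ccc(C(C)(C)C)cc3)cc2c1`: > 10000 nM

Two compounds have been run in a toxicity assay on MDCK cells (Canis lupus familiaris) for cytotoxicity, read by crystal violet staining, with a stated time of 48 h; on this read-out lower numbers stand for higher toxicity in this test and higher numbers for lower toxicity in this test. Compound 1 returned only a limit, > 33000 nM, as described by the limit of > 33000 nM in this assay, at which 1 of the 2 values shown sits. Compound 2 likewise returned only a limit, > 10000 nM, which is the limit of > 10000 nM in this assay, at which 1 of the 2 values shown sits. Neither value is a number, so no step between compound 1 and compound 2 can be counted, and compound 2 stands at one of two limits shown for this assay.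

Compound 3 `Cc1ccc2[nH]c(=O)c(CN(Cc3ccc(SC(F)(F)F)cc3)Cc3ccc(C(C)(C)C)cc3)cc2c1` has not been measured. It differs from compound 2 by 4-((trifluoromethyl)sulfanyl)phenyl in place of 2-hydroxyethyl on a saturated chain carbon bound to an amine nitrogen. The two compounds share everything else, including the core of compound 2 and the 4-tert-butylbenzyl group on the amine nitrogen.

Among the measured compounds shown here, with no measured step between any two compounds, the expected size of the change from compound 2 to compound 3 in this assay rests on the structural change alone; the step that the limit leaves unreadable from compound 2 to compound 3 is expected to be small, close to the scatter, and if anywhere, toward higher toxicity. Compound 3 is expected to give 12000 nM, within 3500 nM to 40000 nM, with a fair chance that this assay again reports only a limit.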

Compound 3, half-maximal cytotoxic concentration: > 5000 nM
Compound 3 was reported as a limit; the forecaster's own chance of this, stated with the estimate: 45%; the middle value lies beyond the limit too.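

In this assay compound 3 gives > 5000 nM, a limit and not a number. Among the compounds shown here, compound 2 also has only a limit, so no step between compound 2 and compound 3 can be read. The compounds shown leave open whether 4-((trifluoromethyl)sulfanyl)phenyl in place of 2-hydroxyethyl changes the read-out in this assay at all.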